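The compounds below may be only part of what the source reports. "The series", "measured", "known", "first", "only" and "open" are said of these compounds alone.

In a functional assay for inhibition, with Homo sapiens as the target (a lower number here means tighter binding, a higher number weaker binding), compound 1 `N#Cc1ccc(C2OCC(C/C=C\CCC(=O)O)C(c3cccnc3)O2)cc1` gives 1290 nM, compound 2 `O=C(O)CC/C=C\CC1COC(c2ccc([N+](=O)[O-])cc2)OC1c1cccnc1` gives 933 nM and compound 3 `O=C(O)CC/C=C\CC1COC(c2ccsc2)OC1c1cccnc1` gives 1580 nM. Compound 3 therefore stands level with the other two within the scatter, and they also stand level with each other: a 1.4-fold lower number from compound 1 to compound 2 (0.14 log units; within the scatter). Compound 4 `O=C(O)CC/C=C\CC1COC(c2cccc3ccccc23)OC1c1cccnc1` has not yet been measured. It carries naphthalen-1-yl in place of thiophen-3-yl on a saturated ring carbon. Two measured steps changed the group on this same ring carbon: a 1.2-fold higher number from compound 1 to compound 3 (0.09 log units; within the scatter), and a 1.7-fold higher number from compound 2 to compound 3 (0.23 log units; within the scatter). Among the compounds with values here, neither went beyond the scatter, although no measured compound carries naphthalen-1-yl, so that group itself remains untested. On this evidence, no step beyond the scatter is expected in this assay. The expected change is a 1.2-fold lower number from compound 3 to compound 4 (0.08 log units; within the scatter). The estimate for compound 4 is 1300 nM, with an expected range from 500 nM to 3200 nM.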

Compound 4, dissociation constant: 631 nM
For compound 4 the middle estimate is 2.1-fold (0.31 log units) above the measured one, and the stated range covers the measured number.
By their numbers in this assay, from the lowest: compounds 4, 2, 1 and 3 (each within the scatter of the next, the first and the last beyond it).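

At the saturated ring carbon between two ring oxygen atoms, a change of group now moves the number beyond the scatter in this assay (a 2.5-fold lower number from compound 3 to compound 4 (0.40 log units; beyond the scatter)), and naphthalen-1-yl in place of 4-cyanophenyl does the same (a 2.0-fold lower number from compound 1 to compound 4 (0.31 log units; beyond the scatter)), though both steps are modest and none of the earlier changes here went that far. Naphthalen-1-yl is not separated from 4-nitrophenyl, however (a 1.5-fold lower number from compound 2 to compound 4 (0.17 log units; within the scatter)), so this position does not simply reward the larger group, and compound 2 goes against any such reading. Nothing measured here accounts for these differences.

The compounds shown leave open how an unsubstituted phenyl, a cyclohexyl or a naphthalen-2-yl group would stand at this ring carbon. They also leave open whether the naphthalen-1-yl step would hold with a phenyl group in place of the pyridin-3-yl group.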